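Imidazolyl in place of pyridyl: expected metabolic stability

The source may report more compounds than this note shows. Statements on the series, on what has been measured and on what is new or still open speak of the compounds shown alone.

Compound 3 `CNC(=O)c1ccc(-c2cnc(NCc3c(F)ccc4c3CCO4)c3cn[nH]c(=O)c23)c(C)n1` gives 23 mL.min-1.g-1 in an ADME assay on microsomes from liver (Homo sapiens) for metabolic stability, read by LC-MS, using NADPH, with stated times of 5 min and 30 min, tested at 1 uM (on this read-out higher numbers stand for fast clearance and lower numbers for slow clearance), the second highest of three numbers. Compound 2 `Cc1cc(-c2cnc(NCc3c(F)ccc4c3CCO4)c3cn[nH]c(=O)c23)n(C)n1` gives 24 mL.min-1.g-1, and a 1.0-fold lower number from compound 2 to compound 3 (0.02 log units; within the scatter). Compound 1 `Cc1nccn1-c1cnc(NCc2c(F)ccc3c2CCO3)c2cn[nH]c(=O)c12` gives 8 mL.min-1.g-1, the lowest number. Compound 4 `CNC(=O)c1ncc(-c2cnc(NCc3c(F)ccc4c3CCO4)c3cn[nH]c(=O)c23)n1C` has not been measured; it differs from compound 3 in one place: 1-methyl-2-(methylcarbamoyl)-1H-imidazol-5-yl in place of 2-methyl-6-(methylcarbamoyl)pyridin-3-yl on an aromatic carbon. The steps bearing on this change are a 2.9-fold higher number from compound 1 to compound 3 (0.46 log units; beyond the scatter) and a 3.0-fold higher number from compound 1 to compound 2 (0.48 log units; beyond the scatter), both modest rises when the 2-methyl-1H-imidazol-1-yl of compound 1 was replaced. The imidazolyl entering compound 4 is not the same group, so only a partial reversal is expected: a 1.6-fold lower number from compound 3 to compound 4 (0.22 log units; within the scatter). Compound 4 is therefore estimated at 14 mL.min-1.g-1, with a range from 6 mL.min-1.g-1 to 30 mL.min-1.g-1.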

Compound 4, intrinsic clearance in microsomes: 24 mL.min-1.g-1
For compound 4 the middle estimate is 1.7-fold (0.23 log units) below the measured one, within the range that was stated.
By their numbers in this assay, from the lowest: compound 1; then compounds 3, 2 and 4 (each within the scatter of the next).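

In this assay, putting the 1-methyl-2-(methylcarbamoyl)-1H-imidazol-5-yl at this aromatic carbon gave a result level with the pyridinyl of compound 3 (a 1.0-fold higher number from compound 3 to compound 4 (0.02 log units; within the scatter)) and the pyrazolyl of compound 2 (no change at the digits printed from compound 2 to compound 4 (within the scatter)). A five-membered aromatic ring carrying the methylcarbamoyl therefore did not return the number to that of compound 1 (a 3.0-fold higher number from compound 1 to compound 4 (0.48 log units; beyond the scatter)), so among these compounds only the 2-methyl-1H-imidazol-1-yl stands apart. Nothing available explains this difference.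
Open, as far as these compounds go, is whether a carboxylic acid or a primary amide in place of the methylcarbamoyl on the imidazolyl would behave the same way.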